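The source may report more compounds than this note shows. Statements on the series, on what has been measured and on what is new or still open speak of the compounds shown alone.

In a physicochemical assay for solubility, measured as kinetic solubility (a higher number here means a more soluble compound, a lower number a less soluble compound), compound 1 (`CC(=O)Nc1cc(-c2ccc(N(C)C(=O)c3c(F)cccc3Cl)c(N3CC4CC4C3)c2)n(C2CCCC2)n1`) gives 0.1 ug/mL, compound 2 (`CC(=O)Nc1cc(-c2ccc(N(C)C(=O)c3c(F)cccc3Cl)c(N3CC4CC4C3)c2)n(C2CCC2)n1`) gives 0.5 ug/mL and compound 3 (`CC(=O)Nc1cc(-c2ccc(N(C)C(=O)c3c(F)cccc3Cl)c(N3CC4CC4C3)c2)n(C(C)C)n1`) gives 2.1 ug/mL, the highest of the three. The measured steps are a 5.0-fold higher number from compound 1 to compound 2 (0.70 log units; beyond the scatter), a 4.2-fold higher number from compound 2 to compound 3 (0.62 log units; beyond the scatter) and, across the whole run, a 21-fold higher number from compound 1 to compound 3 (1.32 log units; beyond the scatter). Each replaces only the group on an aromatic nitrogen.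

Compound 4 (`CC(=O)Nc1cc(-c2ccc(N(C)C(=O)c3c(Cl)cccc3Cl)c(N3CC4CC4C3)c2)n(C(C)C)n1`) keeps the isopropyl group of compound 3 and changes elsewhere: chloro in place of fluoro on an aromatic carbon. This is chloro in place of fluoro on an aromatic carbon, turning 2-chloro-6-fluorophenyl into 2,6-dichlorophenyl. Among the measured compounds shown here, none of the measured steps touches this halogen, so they bear on the change only indirectly, and their modest to large sizes do not carry over. The series holds no direct halogen comparison. Only a small move is therefore expected in this assay, leaning towards a lower number and staying within the scatter. The estimated step is a 1.8-fold lower number from compound 3 to compound 4 (0.24 log units; within the scatter). The expected value for compound 4 is 1.2 ug/mL, within an estimated range of 0.3 ug/mL to 3.5 ug/mL.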

Compound 4, solubility: 0.8 ug/mL
For compound 4 the middle estimate is 1.5-fold (0.18 log units) above the measured one; measured number inside the range.
By their numbers in this assay, from the lowest: compound 1; then compounds 2 and 4 (each within the scatter of the next); then compound 3.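

Turning 2-chloro-6-fluorophenyl into 2,6-dichlorophenyl gives a 2.6-fold lower number from compound 3 to compound 4 (0.42 log units; beyond the scatter) in this assay, so this halogen position registers in this read-out even though the swap exchanges one heavy atom for one heavy atom and leaves the counted donors, acceptors and charge unchanged. Among the compounds shown here, all earlier steps sat on the aromatic nitrogen, so this is the first sign that the number also responds to a change on an aromatic carbon, ortho to a large group, with the isopropyl group held constant. No measured data on this pair account for the drop.

The compounds shown leave open whether this step holds with cyclobutyl or cyclopentyl on the aromatic nitrogen. On these data alone, how a methoxy group or a nitrile would read at this same place also remains open.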